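Oxan-4-yl in place of benzyl on the amine nitrogen

The source may report more compounds than this note shows. Statements on the series, on what has been measured and on what is new or still open speak of the compounds shown alone.

In an in vitro ADME assay on microsomes from liver (Homo sapiens) for pharmacokinetics, read by LC-MS, with a stated time of 10 min, tested at 1 uM (on this read-out lower numbers stand for slow clearance and higher numbers for fast clearance), compound 1 (`CCN1C[C@H](C(=O)Nc2ccc(Cl)cc2)[C@@H](c2ccc(/C=C/C(=O)Nc3ccccc3N)cc2)C1`) gives 12 mL/min/kg, compound 2 (`CC(C)(C)N1C[C@H](C(=O)Nc2ccc(Cl)cc2)[C@@H](c2ccc(/C=C/C(=O)Nc3ccccc3N)cc2)C1`) gives 8 mL/min/kg and compound 3 (`Nc1ccccc1NC(=O)/C=C/c1ccc([C@H]2CN(Cc3ccccc3)C[C@@H]2C(=O)Nc2ccc(Cl)cc2)cc1`) gives 3 mL/min/kg, the lowest of the three. Compound 4 (`Nc1ccccc1NC(=O)/C=C/c1ccc([C@H]2CN(C3CCOCC3)C[C@@H]2C(=O)Nc2ccc(Cl)cc2)cc1`) carries oxan-4-yl in place of benzyl on the amine nitrogen in a ring: oxan-4-yl in place of benzyl on an amine nitrogen in a ring. Among the compounds with values here, three measured steps bear on this position: a 1.5-fold lower number from compound 1 to compound 2 (0.18 log units; within the scatter), a 4.0-fold lower number from compound 1 to compound 3 (0.60 log units; beyond the scatter) and a 2.7-fold lower number from compound 2 to compound 3 (0.43 log units; beyond the scatter). Among these compounds, only benzyl carries an aromatic ring at this position, and oxan-4-yl has none. Within the data shown here, no measured compound carries oxan-4-yl, so a partial reversal of a 2.7-fold lower number from compound 2 to compound 3 (0.43 log units; beyond the scatter) is only a working expectation. The estimated step is a 2.0-fold higher number from compound 3 to compound 4 (0.30 log units; within the scatter), towards a higher number. For compound 4 the expected clearance is 6 mL/min/kg, with an estimated range from 2.5 mL/min/kg to 14 mL/min/kg.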

Compound 4, clearance: 12 mL/min/kg
Estimate against measurement, compound 4: 2.0-fold (0.30 log units) below; measured number inside the range.
By their numbers in this assay, from the lowest: compound 3; then compounds 2, 1 and 4 (each within the scatter of the next).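

In this assay the low number of compound 3 does not carry over to oxan-4-yl (a 4.0-fold higher number from compound 3 to compound 4 (0.60 log units; beyond the scatter)), so a six-membered ring on the amine nitrogen is not enough by itself. Compound 4 instead sits with tert-butyl (a 1.5-fold higher number from compound 2 to compound 4 (0.18 log units; within the scatter)) and ethyl (no change at the digits printed from compound 1 to compound 4 (within the scatter)), which leaves benzyl, the only aromatic ring among these groups, standing alone. Nothing at hand explains the gap between benzyl and oxan-4-yl.

On these data alone, whether the low number follows the aromatic ring or the carbon link of benzyl stays open: phenyl directly on the amine nitrogen, or cyclohexylmethyl, would separate the two.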